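Swapping the amide aryl for a thiazole in compound 1

A few compounds are considered here, and "the series" means these few. Any claim that something is new, unique, unknown or untested is made for them only; others in the source may bear on it.

Measured compounds:
compound 1 `Cc1ccc(C(=O)Nc2cccc(-c3ccnc4c(N)cccc34)c2)cc1C` — > 20000 nM
compound 2 `Nc1cccc2c(-c3cccc(NC(=O)c4ccc(Cl)c(C(F)(F)F)c4)c3)ccnc12` — 1400 nM

Compound 1 `Cc1ccc(C(=O)Nc2cccc(-c3ccnc4c(N)cccc34)c2)cc1C` carries a 3,4-dimethylphenyl group on the amide carbonyl. In a functional assay on A375P cells (Homo sapiens) for antiproliferative activity, read by MTT assay, with a stated time of 48 h (a lower number here means a stronger inhibitor, a higher number a weaker inhibitor), compound 1 gives only a limit, > 20000 nM, so its true potency is not known, only that it sits at the limit of > 20000 nM in this assay, at which 1 of the 2 values shown sits. Compound 2 `Nc1cccc2c(-c3cccc(NC(=O)c4ccc(Cl)c(C(F)(F)F)c4)c3)ccnc12` shares the core of compound 1 and differs at the amide aryl; in this assay compound 2 gives 1400 nM, a number rather than a limit. Among the measured compounds shown here, no single-point step between measured compounds connects these two, so the data show only what the two values are.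

Compound 3 `Nc1cccc2c(-c3cccc(NC(=O)c4nccs4)c3)ccnc12` is the next compound, not yet measured. It differs from compound 1 by 1,3-thiazol-2-yl in place of 3,4-dimethylphenyl on a carbonyl carbon. Because compound 1 gives > 20000 nM as a limit, a step from it can only be expected to move toward a number, and compound 3 is estimated to be moderately stronger, a step of an at least 1.6-fold lower number from compound 1 to compound 3 (0.22 log units; that floor lies within the scatter) in this assay. Compound 3 is therefore estimated at 12000 nM in this assay, within 2500 nM to 50000 nM, with a real chance that the assay again reports only a limit.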

Compound 3, half-maximal inhibitory concentration: 16700 nM
Beside the measured number, compound 3's estimate is 1.4-fold (0.14 log units) below it; low and high end bracket the measured number.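

Compound 3 shows that a five-membered aromatic ring with 2 hetero atoms on the carbonyl carbon gives a measured number in this assay: compound 3 reads 16700 nM, while compound 2, with its different amide aryl, reads 1400 nM. The change from 3,4-dimethylphenyl to 1,3-thiazol-2-yl is read as an at least 1.1-fold lower number from compound 1 to compound 3 (0.07 log units; that floor lies within the scatter), so these data establish no real gain from the swap. The true size of the step cannot be read, because the value of compound 1 is a limit and not a number: the limit of > 20000 nM in this assay, at which 1 of the 3 values shown sits.

The change from compound 1 to compound 3 alters the ring size, the hetero atoms and the two methyl groups all at once, so the compounds shown leave open which of these matters at this position. They also leave open how an unsubstituted phenyl, a pyridin-2-yl ring or a 1,3-thiazol-2-yl ring carrying a chlorine or a methyl group would read in this assay.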